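Nitro substitution on two related cores: working notes

The compounds below may be only part of what the source reports. "The series", "measured", "known", "first", "only" and "open" are said of these compounds alone.

Measured in a functional assay on SGC-7901 cells (Homo sapiens) for antiproliferative activity, read by MTT assay, with a stated time of 72 h; a lower number here means a stronger inhibitor, a higher number a weaker inhibitor:
compound 1 `COc1ccc(-c2c(-c3cc(OC)c(OC)c(OC)c3)ssc2=S)cc1`: 2350 nM
compound 2 `COc1ccc(-c2c(-c3cc(OC)c(OC)c(OC)c3)ssc2=S)cc1[N+](=O)[O-]`: 44700 nM
compound 3 `COc1ccc(-c2c(-c3cc(OC)c(OC)c(OC)c3)ss/c2=N/O)cc1`: > 100000 nM, which is a limit of the assay and not a number.

Compound 2 differs from compound 1 by nitro in place of hydrogen on an aromatic carbon. In this assay the change gave a 19-fold higher number from compound 1 to compound 2 (1.28 log units; beyond the scatter), so the nitro compound is clearly the weaker of the pair.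

Compound 4 `COc1ccc(-c2c(-c3cc(OC)c(OC)c(OC)c3)ss/c2=N/O)cc1[N+](=O)[O-]` has not been measured. Going by the values given here, it differs from compound 3 by nitro in place of hydrogen on an aromatic carbon, the same change as the one from compound 1 to compound 2, made here on the core of compound 3. The difference between the two cores, that of compound 1 and that of compound 3, is not broken down here. Compound 3 sits at the limit of > 100000 nM in this assay, at which 1 of the 3 values shown sits.

Compound 4 is expected to move by a step that the limit leaves unreadable from compound 3 to compound 4 in this assay, an expectation that rests on the earlier 19-fold higher number from compound 1 to compound 2 (1.28 log units; beyond the scatter), which ran toward a higher number. Since compound 3 already gives only a limit, the expected value for compound 4 is 400000 nM, within a range from 100000 nM to 2000000 nM, and this assay is expected once more to report only a limit for compound 4.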

Compound 4, half-maximal inhibitory concentration: 6560 nM
For compound 4 the middle estimate is 61-fold (1.79 log units) above the measured one; measured number below the stated range.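

Nitro in place of hydrogen on an aromatic carbon does not carry from the core of compound 1 to the core of compound 3 as a fixed step: in this assay it gave an at least 15-fold lower number from compound 3 to compound 4 (1.18 log units; beyond the scatter), and the two steps on the two cores run in opposite directions: the same change on two cores in this assay, a 19-fold higher number (1.28 log units; beyond the scatter) from compound 1 to compound 2 and an at least 15-fold lower number (1.18 log units; beyond the scatter) from compound 3 to compound 4, at least 280-fold (2.46 log units) apart, beyond the scatter of two such steps.

Compound 3 gives > 100000 nM, which is a limit of the assay and not a number, so the step on that core has a direction and a minimum size but no exact size.

The reversal rests on two pairs only, one on each core, and it does not show why the direction differs, nor does it give a rule for any further core or for any other group.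

The compounds shown leave open whether the split between the two cores belongs to the nitro group alone, or whether an amine or a carboxylic acid in the same place, ortho to a methoxy group, would also move in opposite directions on the two cores. They also leave open whether the reversal seen on these SGC-7901 cells would hold on other cell lines.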